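A few compounds are considered here, and "the series" means these few. Any claim that something is new, unique, unknown or untested is made for them only; others in the source may bear on it.

Compound 1, `Nc1nn(C(=O)Nc2ccc(Cc3ccccc3)cc2)c2ccccc12`, carries no result: in a functional assay on NCI/ADR-RES cells (Homo sapiens) for antiproliferative activity, read by sulforhodamine B assay, with a stated time of 48 h (a higher number here means that more compound is tolerated, a lower number that less compound is tolerated), compound 1 gives "not determined" (no result reported). Compound 2, `Nc1nn(C(=O)Nc2ccc(Cc3ccccc3)cc2)c2ccc(Cl)cc12`, is known only as a limit: in this assay compound 2 gives > 100000 nM. That is a limit of the assay and not a number; compound 2 sits at the limit of > 100000 nM in this assay, at which 1 of the 2 values shown sits. Compound 3, `Nc1ccc2c(c1)c(N)nn2C(=O)Nc1ccc(Cc2ccccc2)cc1`, differs from compound 2 by amino in place of chloro on an aromatic carbon. Among the measured compounds shown here, no step between measured compounds is known, so in this assay a shift of no more than the scatter is expected. Compound 3 is estimated at 100000 nM, between 30000 nM and 300000 nM. The expected step is a number no higher from compound 2 to compound 3 (the limit leaves the size open), nothing beyond the scatter.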

Compound 3, concentration lethal to 50% of the cells: > 100000 nM
Compound 3: a limit, no number (the forecaster's own chance of this, stated with the estimate: 70%); the middle value lies on the limit itself.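

Among the compounds shown here, compound 2 and compound 3 are both known in this assay only as limits, so no step between them can be read. The compounds shown leave open whether amino in place of chloro changes the lethal concentration at all.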